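Tetrazole in place of thiadiazole on the thioether sulfur

A few compounds are considered here, and "the series" means these few. Any claim that something is new, unique, unknown or untested is made for them only; others in the source may bear on it.

Compound 1 `Cc1nnc(SCC(=O)N/N=c2/scc(-c3ccc(C#N)cc3)n2-c2ccccc2)s1` stands at the lower end of the numbers available. In an ADME assay on NIH3T3 cells (Mus musculus) for cytotoxicity, read by MTT assay, with a stated time of 24 h (on this read-out lower numbers stand for stronger inhibition and higher numbers for weaker inhibition), compound 1 gives < 3.9 ug/mL, which is a limit of the assay and not a number (the limit of < 3.9 ug/mL in this assay, at which 1 of the 2 values shown sits). Compound 2 `Cc1nnc(SCC(=O)N/N=c2/scc(-c3ccc(Br)cc3)n2-c2ccccc2)s1` differs from compound 1 in the aryl substituent only; in this assay compound 2 gives 55 ug/mL. Among the compounds with values here, the step of an at least 14-fold higher number from compound 1 to compound 2 (1.14 log units; beyond the scatter) is the one measured step. Compound 3 `N#Cc1ccc(-c2cs/c(=N/NC(=O)CSc3nnnn3-c3ccccc3)n2-c2ccccc2)cc1` carries the change (1-phenyl-1H-tetrazol-5-yl in place of 5-methyl-1,3,4-thiadiazol-2-yl on a sulfur). The measured step concerns bromo in place of cyano on an aromatic carbon and does not touch this sulfur, so it does not bear on the change from compound 1 to compound 3. With compound 1 at a limit, the step of an at least 1.2-fold higher number from compound 1 to compound 3 (0.10 log units; that floor lies within the scatter) is expected to stay within the scatter, in no set direction. For compound 3 the estimate in this assay is 5 ug/mL, with a range from 1.5 ug/mL to 20 ug/mL.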

Compound 3, half-maximal inhibitory concentration: 453 ug/mL
Compound 3: the middle estimate sits 91-fold (1.96 log units) below what was measured; measured number outside the range, above it.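

The group on the sulfur carries weight in this assay: 1-phenyl-1H-tetrazol-5-yl in place of 5-methyl-1,3,4-thiadiazol-2-yl gives an at least 110-fold higher number from compound 1 to compound 3 (2.06 log units; beyond the scatter), with the aryl nitrile kept. Within the data shown here, the earlier pair showed a change only at the aryl substituent, so this is the first sign that the read-out also responds at this sulfur. Compound 1 stands at a limit of the assay, so the step is a floor and its true size stays unknown: the limit of < 3.9 ug/mL in this assay, at which 1 of the 3 values shown sits.

The tetrazole ring and the added phenyl ring enter together, so the compounds shown do not tell which of them carries the step; a 1-methyl-1H-tetrazol-5-yl group on the sulfur would separate the two. On these data alone, whether the bromo in place of cyano step holds alongside the tetrazole also remains open.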